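This account rests on a few compounds, and the source may have more. Where it says the series, first, only, none or still open, it means among the compounds named here.

Compound 1 (`Cc1cc(C)cc(NC(=O)[C@@H]2CCCN2S(=O)(=O)c2cccc3cccnc23)c1`) gives 31300 nM
Compound 2 (`Cc1cccc(C)c1NC(=O)[C@@H]1CCCN1S(=O)(=O)c1cccc2cccnc12`) gives > 50000 nM (a limit of the assay)
Compound 3 (`COc1ccc(C)c(NC(=O)[C@@H]2CCCN2S(=O)(=O)c2cccc3cccnc23)c1`) gives 44200 nM

In an ADME assay on HEp-2 cells (Homo sapiens) for cytotoxicity (a higher number here means that more compound is tolerated, a lower number that less compound is tolerated), compound 3 gives 44200 nM and sits within the scatter of compound 1. Compound 2 gives only a limit, not a number: > 50000 nM.

Compound 4 (`COc1ccc(C)cc1NC(=O)[C@@H]1CCCN1S(=O)(=O)c1cccc2cccnc12`) has the same atoms as compound 3, joined differently: 2-methoxy-5-methylphenyl in place of 5-methoxy-2-methylphenyl on an amide-type nitrogen. In words, 2-methoxy-5-methylphenyl stands in place of 5-methoxy-2-methylphenyl on an amide-type nitrogen.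

Among the compounds with values here, no measured step makes this exact swap, but three others change the group on that same nitrogen. They read a 1.4-fold higher number from compound 1 to compound 3 (0.15 log units; within the scatter), an at least 1.5-fold higher number from compound 1 to compound 2 (0.20 log units; that floor lies within the scatter) and an at least 1.1-fold lower number from compound 2 to compound 3 (0.05 log units; that floor lies within the scatter). None of them shows a change beyond the scatter, so no step beyond the scatter is expected here in this assay. The expected step is a 1.1-fold lower number from compound 3 to compound 4 (0.04 log units; within the scatter). For compound 4 the estimated value is 40000 nM, with an expected range from 22000 nM to 50000 nM.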

Compound 4, half-maximal cytotoxic concentration: > 50000 nM
Compound 4: a limit, no number; the forecaster's own chance of this, stated with the estimate: 30%; at least 1.2-fold (0.09 log units) between middle value and limit.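

In this assay, rearranging the same atoms from 5-methoxy-2-methylphenyl to 2-methoxy-5-methylphenyl on the amide-type nitrogen gives an at least 1.1-fold higher number from compound 3 to compound 4 (0.05 log units; that floor lies within the scatter), while replacing 3,5-dimethylphenyl with 2-methoxy-5-methylphenyl gives an at least 1.5-fold higher number from compound 1 to compound 4 (0.20 log units; that floor lies within the scatter). Within the data shown here, this adds the first pair here with the same atoms joined differently, and it adds a second compound that reads only as a limit, so both new steps are floors and neither shows a change beyond the scatter. The step between compound 2 and compound 4 cannot be read because both compounds sit at the same limit: the limit of > 50000 nM in this assay, at which 2 of the 4 values shown sit.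

From the compounds shown here alone, how far compound 2 and compound 4 lie past that limit stays open. So does whether an amine or a carboxylic acid on the phenyl ring, or a longer chain in its place, would give a step beyond the scatter.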